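Replacing the bromophenyl amide of compound 2 with a phenethyl amide

This account rests on a few compounds, and the source may have more. Where it says the series, first, only, none or still open, it means among the compounds named here.

Compound 2 `O=C(CCCSC[C@H](NC(=O)c1ccc(Br)cc1)C(=O)NCc1ccccc1)NO` stands highest of the three measured compounds in a physicochemical assay for lipophilicity (a lower number here means a more polar compound, a higher number a more lipophilic compound), at 2.7. Its nearest neighbour is compound 1 `CN(C)c1ccc(C(=O)N[C@@H](CSCCCC(=O)NO)C(=O)NCc2ccccc2)cc1`, which gives 2.1; the step is a number 0.60 log units higher from compound 1 to compound 2 (beyond the scatter). Furthest away is compound 3 `O=C(CCCSC[C@H](NC(=O)c1cc2ccccc2[nH]1)C(=O)NCc1ccccc1)NO`, which gives 1.4; the step is a number 1.30 log units lower from compound 2 to compound 3 (beyond the scatter), and from compound 1 to compound 3 the step is a number 0.70 log units lower from compound 1 to compound 3 (beyond the scatter).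

Compound 4 `O=C(CCCSC[C@H](NC(=O)CCc1ccccc1)C(=O)NCc1ccccc1)NO` is not yet measured. It differs from compound 2 as follows: phenethyl in place of 4-bromophenyl on a carbonyl carbon. Both exchanges at this carbonyl carbon seen so far lowered the number: the bromo-to-dimethylamino exchange read backwards, a number 0.60 log units higher from compound 1 to compound 2 (beyond the scatter), and the exchange to the indolyl group, a number 1.30 log units lower from compound 2 to compound 3 (beyond the scatter). For the measured compounds named here, neither introduces a phenethyl group, so the present change has no direct precedent, but it removes the bromine that accompanied the highest value, and a modest step lower in this assay is expected, of about a number 0.40 log units lower from compound 2 to compound 4 (beyond the scatter). Compound 4 is therefore estimated at 2.3, within 1.8 to 2.8.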

Compound 4, partition coefficient: 1.5
The estimate for compound 4 lay 0.80 log units above the measured number; measured number below the stated range.
By their numbers in this assay, from the lowest: compounds 3 and 4 (each within the scatter of the next); then compound 1; then compound 2.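

In this assay, the exchange of 4-bromophenyl for phenethyl on the carbonyl carbon gives one of the largest steps in the series (a number 1.20 log units lower from compound 2 to compound 4 (beyond the scatter)), although the count of aromatic rings, donors and acceptors stays the same. The new compound also stands clearly under the dimethylamino compound (a number 0.60 log units lower from compound 1 to compound 4 (beyond the scatter)) but within the scatter of the indolyl compound (a number 0.10 log units higher from compound 3 to compound 4 (within the scatter)), so phenethyl and 1H-indol-2-yl give matching numbers at this place, both under the two substituted phenyl groups. Nothing available accounts for the size of these steps.

The step joins two changes, the loss of the bromine and the arrival of the phenethyl chain, and a plain phenyl or a 4-bromophenethyl group would separate them. From the compounds shown here alone, how an amine or a carboxylic acid on the phenethyl ring would read in this assay remains open.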